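The source may hold more compounds than are shown below. What is called first, only, known or untested is meant among the compounds shown, and "the series" means these compounds.

Three compounds share one core and differ only in the aryl group attached to it. Compound 1 `Cc1nc2c3ccccc3ccc2c2nc3c(ccc4ccccc43)c(-c3cccnc3)c12` carries a pyridin-3-yl group, and in a functional assay on AGS cells (Homo sapiens) for cytotoxicity, read by MTT assay, with a stated time of 48 h (a higher number here means a weaker inhibitor, a lower number a stronger inhibitor), compound 1 gives 3960 nM. Compound 2 `Cc1nc2c3ccccc3ccc2c2nc3c(ccc4ccccc43)c(-c3nccnc3N)c12` carries a 3-aminopyrazin-2-yl group, and in this assay compound 2 gives 2260 nM; the step of a 1.8-fold lower number from compound 1 to compound 2 (0.24 log units; within the scatter) does not separate the two. Compound 3 `COc1ccc(-c2c3ccc4ccccc4c3nc3c2c(C)nc2c4ccccc4ccc32)cc1` carries a 4-methoxyphenyl group, and in this assay compound 3 gives 66400 nM, the highest of the three numbers, with a 17-fold higher number from compound 1 to compound 3 (1.22 log units; beyond the scatter) and a 29-fold higher number from compound 2 to compound 3 (1.47 log units; beyond the scatter) both beyond the scatter, so compound 3 is the weakest inhibitor shown. Compound 4 `Cc1nc2c3ccccc3ccc2c2nc3c(ccc4ccccc43)c(-c3cccc4ccccc34)c12` has not been measured. The change from compound 3 is naphthalen-1-yl in place of 4-methoxyphenyl on an aromatic carbon. The measured steps that bear on it are the two into compound 3, a 17-fold higher number from compound 1 to compound 3 (1.22 log units; beyond the scatter) and a 29-fold higher number from compound 2 to compound 3 (1.47 log units; beyond the scatter): both were large, and in both a ring containing nitrogen gave way to a ring of carbon only. Compound 4 likewise carries a group of carbon only, without any hydrogen-bond acceptor, so no clear return toward the number of compound 1 is expected. For compound 4 only a modest step of a 2.2-fold lower number from compound 3 to compound 4 (0.35 log units; beyond the scatter) in this assay is expected, and its direction is uncertain. Compound 4 is therefore estimated at 30000 nM in this assay, within a range from 7000 nM to 120000 nM.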

Compound 4, half-maximal inhibitory concentration: 12100 nM
Estimate against measurement, compound 4: 2.5-fold (0.39 log units) above, and the stated range covers the measured number.
By their numbers in this assay, from the lowest: compounds 2 and 1 (each within the scatter of the next); then compound 4; then compound 3.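

In this assay, the change to naphthalen-1-yl gives a 5.5-fold lower number from compound 3 to compound 4 (0.74 log units; beyond the scatter), so among the carbon-only aryl groups at this position the choice of group moves the number, and the group with no hydrogen-bond acceptor gives the lower number of the two. Even so, the naphthalen-1-yl group does not match either nitrogen-containing ring, with a 3.1-fold higher number from compound 1 to compound 4 (0.49 log units; beyond the scatter) and a 5.4-fold higher number from compound 2 to compound 4 (0.73 log units; beyond the scatter), so in these four compounds both groups of carbon only give higher numbers than both nitrogen-containing rings, and no compound goes against this order. No measurement shown here explains these differences.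

The compounds shown leave open whether the step between compound 3 and compound 4 follows from losing the methoxy group or from gaining the second fused aromatic ring, a question that a plain phenyl group at the same position would help to separate. They also leave open how an amine or a carboxylic acid on the aryl ring, or naphthalen-2-yl in place of naphthalen-1-yl, would behave here.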